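The source may report more compounds than this note shows. Statements on the series, on what has been measured and on what is new or still open speak of the compounds shown alone.

Measured compounds: compound 1 `COC1=C(CC(C)(C)CNC(=O)c2ccccc2OC)C(=O)c2ccccc2C1=O`, 33200 nM; compound 2 `COc1ccccc1C(=O)NCC(C)(C)CC1=C(O)C(=O)c2ccccc2C1=O`, 26300 nM; compound 3 `COc1cc(C(=O)NCC(C)(C)CC2=C(O)C(=O)c3ccccc3C2=O)c(OC)c2ccccc12`, 47000 nM.

In a functional assay on KB cells (Homo sapiens) for cytotoxicity, read by resazurin assay, with a stated time of 3 days (a lower number here means a stronger inhibitor, a higher number a weaker inhibitor), these three compounds give numbers that all lie within the scatter of one another. Compound 2 and compound 1 differ by one change, (methyl in place of hydrogen on an oxygen on an unsaturated carbon), and this gave a 1.3-fold higher number from compound 2 to compound 1 (0.10 log units; within the scatter). The difference between compound 2 and compound 3 is not broken down here. Compound 4 `COC1=C(CC(C)(C)CNC(=O)c2cc(OC)c3ccccc3c2OC)C(=O)c2ccccc2C1=O` is not yet measured; it differs from compound 3 by methyl in place of hydrogen on an oxygen on an unsaturated carbon, the same change as that from compound 2 to compound 1, at the same place. Because a 1.3-fold higher number from compound 2 to compound 1 (0.10 log units; within the scatter) stayed within the scatter, a step of similar size, a 1.3-fold higher number from compound 3 to compound 4 (0.11 log units; within the scatter), is expected here. In this assay compound 4 is therefore estimated at 60000 nM, between 25000 nM and 150000 nM.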

Compound 4, half-maximal inhibitory concentration: 41200 nM
Compound 4: middle estimate off by 1.5-fold (0.16 log units), on the high side; the measured number falls inside the stated range.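

In this assay, going from hydroxy to methoxy gave a 1.1-fold lower number from compound 3 to compound 4 (0.06 log units; within the scatter), a step small enough to sit within the scatter. Set beside the same change on the other core, the two steps agree: the same change on two cores in this assay, a 1.3-fold higher number (0.10 log units; within the scatter) from compound 2 to compound 1 and a 1.1-fold lower number (0.06 log units; within the scatter) from compound 3 to compound 4, 1.4-fold (0.16 log units) apart, within the scatter of two such steps. Among the compounds shown here, this shows that on these two cores the change made no readable difference, but it gives no direction for the step and cannot show that the same would hold on any other core.

The compounds shown leave open whether a longer chain such as ethyl on this oxygen would give a step beyond the scatter. They also leave open how the change behaves on a core carrying an amine or a carboxylic acid.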